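Sulfur for Oxygen on a Carbonyl Carbon

The source may hold more compounds than are shown below. What is called first, only, known or untested is meant among the compounds shown, and "the series" means these compounds.

Compound 2 `CCOC(=O)N1CCC(Oc2ncnc3c2CCN3c2ccc(S(C)(=O)=O)cc2F)CC1` gives 251 nM in a functional assay on CHO-K1 cells for agonist activity at Glucose-dependent insulinotropic receptor (Homo sapiens), read by a luciferase reporter, with a stated time of 5 h (on this read-out higher numbers stand for an effect only at larger amounts of compound and lower numbers for an effect already at smaller amounts), and compound 1 `CC(C)OC(=O)N1CCC(Oc2ncnc3c2CCN3c2ccc(-c3nccs3)cc2F)CC1` gives 79.4 nM.

Within the data shown here, of these two numbers, compound 2 stands at the higher one; its only neighbour, compound 1, lies at a gap beyond the usual scatter. Compound 3 `CCSC(=O)N1CCC(Oc2ncnc3c2CCN3c2ccc(S(C)(=O)=O)cc2F)CC1` differs from compound 2 by ethylsulfanyl in place of ethoxy on a carbonyl carbon. Among the measured compounds shown here, no measured pair shows this change, so the expected step is none beyond the scatter. The step from compound 2 to compound 3 is expected to be a 1.0-fold lower number from compound 2 to compound 3 (0.00 log units; within the scatter). Compound 3 is estimated at 250 nM, with a range from 80 nM to 800 nM.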

Compound 3, half-maximal effective concentration: 31.6 nM
For compound 3 the middle estimate is 7.9-fold (0.90 log units) above the measured one, and the stated range ends above it.
By their numbers in this assay, from the lowest: compound 3; then compound 1; then compound 2.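

Compound 1 and compound 2 differ in more than one place, so neither could isolate this position. In this assay, ethylsulfanyl in place of ethoxy on a carbonyl carbon gives a 7.9-fold lower number from compound 2 to compound 3 (0.90 log units; beyond the scatter), so this position responds to a single-atom exchange even though the heavy-atom and hydrogen-bond counts of the two groups are the same. No available measurement gives a cause for this step.

As far as these compounds go, it remains open whether an ethylamino group or a longer chain on the sulfur would keep this step, and whether the same exchange would do so on compound 1.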